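Fluoro in place of nitro on compound 1

The source may report more compounds than this note shows. Statements on the series, on what has been measured and on what is new or still open speak of the compounds shown alone.

In a functional assay on LNCaP cells (Homo sapiens) for cytotoxicity, read by MTT assay, with a stated time of 24 h (on this read-out higher numbers stand for an effect only at larger amounts of compound and lower numbers for an effect already at smaller amounts), compound 1 (`O=[N+]([O-])c1ccc(N2CCN(CCN3CCN(c4ccc([N+](=O)[O-])cc4)CC3)CC2)cc1`) gives 25200 nM and stands within the scatter of compound 2 (`Fc1ccccc1N1CCN(CCN2CCN(c3ccccc3F)CC2)CC1`) at 40000 nM on these numbers. Compound 3 (`Fc1ccccc1N1CCN(CCCN2CCN(c3ccccc3F)CC2)CC1`) at 10400 nM lies beyond the scatter on the lower side of compound 1. Compound 4 (`O=[N+]([O-])c1ccc(N2CCN(CCN3CCN(c4ccc(F)cc4)CC3)CC2)cc1`) departs from compound 1 by fluoro in place of nitro on an aromatic carbon at a single 4-nitrophenyl, which becomes 4-fluorophenyl. For the measured compounds named here, no measured pair isolates this change. Compound 2 carries fluoro and no nitro, yet its 40000 nM stays within the scatter of compound 1. The expected 1.2-fold higher number from compound 1 to compound 4 (0.08 log units; within the scatter) is therefore none beyond the scatter. For compound 4 the estimated value is 30000 nM with an expected range (13000 nM to 65000 nM).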

Compound 4, half-maximal effective concentration: 77900 nM
For compound 4 the middle estimate is 2.6-fold (0.41 log units) below the measured one, outside the stated range (above it).
By their numbers in this assay, from the lowest: compound 3; then compounds 1, 2 and 4 (each within the scatter of the next, the first and the last beyond it).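

In this assay, fluoro in place of nitro on an aromatic carbon at one 4-nitrophenyl gives a 3.1-fold higher number from compound 1 to compound 4 (0.49 log units; beyond the scatter) and so shows that this single position affects the read-out, with the other 4-nitrophenyl unchanged. Compounds 2 and 3 each differ from compound 1 in more than one place and could not isolate this position. No available evidence bears on the reason for this step.

The compounds shown leave open whether an amine or a chloro group at this carbon would shift the number. They also leave open whether the same change on the remaining 4-nitrophenyl would give a further step.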